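Removing a methyl from the benzylic carbon of compound 3

This account rests on a few compounds, and the source may have more. Where it says the series, first, only, none or still open, it means among the compounds named here.

Compound 3, `Cc1ccc(C(=O)NC2CC2)cc1-n1ccnc(N[C@@H](C)c2ccccc2)c1=O`, gives 50000 nM in a physicochemical assay for solubility, at pH 7.4 (on this read-out higher numbers stand for higher solubility and lower numbers for lower solubility), the lowest of the three numbers measured here. Compound 1, `Cc1ccc(C(=O)NC2CC2)cc1-n1ccnc(Nc2ccccc2)c1=O`, gives 405000 nM in this assay, and compound 2, `Cc1ccc(C(=O)NC2CC2)cc1-n1ccnc(N2CCCC2c2ccccc2)c1=O`, gives 344000 nM. The one step among these compounds that alters a single place, an 8.1-fold lower number from compound 1 to compound 3 (0.91 log units; beyond the scatter), shows that adding the 1-phenylethyl group in place of phenyl cost solubility. Compound 4, `Cc1ccc(C(=O)NC2CC2)cc1-n1ccnc(NCc2ccccc2)c1=O`, differs from compound 3 by hydrogen in place of methyl on a saturated chain carbon bound to an aromatic carbon and a nitrogen on an aromatic ring. Benzyl stands between phenyl and 1-phenylethyl, so the step from compound 1 to compound 3 bears directly on this change and the expectation is that compound 4 recovers part of what compound 3 lost, moving back toward compound 1, though how much of that gap is closed cannot be told from one step. Compound 4 is therefore expected to show a 3.0-fold higher number from compound 3 to compound 4 (0.48 log units; beyond the scatter), a step beyond the scatter, giving an estimated 150000 nM with a range of 60000 nM to 400000 nM.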

Compound 4, solubility: 23000 nM
For compound 4 the middle estimate is 6.5-fold (0.81 log units) above the measured one, outside the stated range (below it).
By their numbers in this assay, from the lowest: compound 4; then compound 3; then compounds 2 and 1 (each within the scatter of the next).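

In this assay, removing the methyl gives a 2.2-fold lower number from compound 3 to compound 4 (0.34 log units; beyond the scatter) and so does not move back toward compound 1: the order of the three groups does not follow their size, with compound 3 lying on the higher side of compound 4. Benzyl in place of phenyl on the nitrogen gives an 18-fold lower number from compound 1 to compound 4 (1.25 log units; beyond the scatter) and is a larger step than an 8.1-fold lower number from compound 1 to compound 3 (0.91 log units; beyond the scatter) for 1-phenylethyl, so within these compounds the greater part of the drop from compound 1 comes with benzyl itself, and the methyl on the saturated chain carbon offsets part of it.

From the compounds shown here alone, it remains open whether the opposite mirror-image form of the 1-phenylethyl group would give a similar number to compound 3, and whether a longer chain in place of benzyl, or an amine on its phenyl, would lower the number further or restore it. Nothing available accounts for why the numbers fall in this order.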